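Compound 3 to compound 4: hydroxymethyl gives way to carboxy

A few compounds are considered here, and "the series" means these few. Any claim that something is new, unique, unknown or untested is made for them only; others in the source may bear on it.

Going by the values given here, in a functional assay on MCF7 cells (Homo sapiens) for inhibition, read by MTT assay, with a stated time of 72 h (a lower number here means a stronger inhibitor, a higher number a weaker inhibitor), compound 3 `CC(C)=CCC[C@H](C)c1ccc(C)c(CNCCCCCO)c1O` gives 7600 nM, the only actual number among the compounds measured so far. Compound 1 `CC(C)=CCC[C@H](C)c1ccc(C)c(CNCCO)c1O` reads > 20000 nM, which is a limit of the assay. Compound 2 `CC(C)=CCC[C@H](C)c1ccc(C)c(CNCC2CCNCC2)c1O` reads > 20000 nM, which is also a limit.

Compound 4 `CC(C)=CCC[C@H](C)c1ccc(C)c(CNCCCCC(=O)O)c1O` keeps the shared core and changes one group of compound 3: carboxy in place of hydroxymethyl on a saturated chain carbon, four bonds along the chain from an amine nitrogen. Carboxy stands in place of hydroxymethyl, on a saturated chain carbon, four bonds along the chain from an amine nitrogen.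

Among the compounds with values here, two measured steps bear on this change, though neither involves carboxy. One is an at least 2.6-fold lower number from compound 1 to compound 3 (0.42 log units; beyond the scatter), with 3-hydroxypropyl in place of hydroxy. The other is an at least 2.6-fold lower number from compound 2 to compound 3 (0.42 log units; beyond the scatter), with 4-hydroxybutyl in place of piperidin-4-yl. Each starts from a limit, so each gives only a minimum size. Together they show that changing this side chain can separate a measurable compound from one that stays at the limit. A move toward a higher number, meaning a weaker inhibitor, therefore seems more likely than a gain. The expected change is a 2.4-fold higher number from compound 3 to compound 4 (0.37 log units; beyond the scatter). For compound 4, the estimated value is 18000 nM, with an expected range of 7000 nM to 45000 nM.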

Compound 4, half-maximal inhibitory concentration: > 20000 nM
Compound 4 ended at the assay's limit; the forecaster's own chance of this, stated with the estimate: 55%; middle value at least 1.1-fold (0.04 log units) away from the limit.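

In this assay, replacing hydroxymethyl with carboxy at the end of the chain, four bonds along from an amine nitrogen, gives an at least 2.6-fold higher number from compound 3 to compound 4 (0.42 log units; beyond the scatter). Compound 4 reads > 20000 nM, which is a limit of the assay. The earlier steps changed the side chain more broadly, whereas this one keeps the chain and changes only its end group, and that single change is enough to take away the only measurable value in the set; the true size of the loss stays unknown, and the steps from compound 1 and compound 2 to compound 4 cannot be read, as both ends of each sit at the same limit: the limit of > 20000 nM in this assay, at which 3 of the 4 values shown sit.

From the compounds shown here alone, it remains open whether this loss is specific to the carboxylic acid or would also follow from other end groups at this place, such as an amine, an amide or a methyl ester. A longer chain ending in hydroxymethyl is also untested among the compounds shown, and with only compound 3 giving a number, compound 1, compound 2 and compound 4 cannot be ranked against one another.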